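Aryl swap at the saturated ring carbon: compound 4

This account rests on a few compounds, and the source may have more. Where it says the series, first, only, none or still open, it means among the compounds named here.

Three members of the series carry a 3,4,5-trimethoxyphenyl group on the ring nitrogen and vary the aryl on the saturated ring carbon. In a functional assay on Ehrlich cells (Mus musculus) for cytotoxicity, tested at 25 ug/mL (on this read-out higher numbers stand for a stronger effect at the one concentration tested and lower numbers for a weaker effect), compound 1 `COc1ccc(C2C(C#N)=C(N)N(c3cc(OC)c(OC)c(OC)c3)C3=C2C(=O)CC(C)(C)C3)cc1` gives 1%, compound 2 `COc1cc(N2C(N)=C(C#N)C(c3c(OC)ccc4ccccc34)C3=C2CC(C)(C)CC3=O)cc(OC)c1OC` gives 5% and compound 3 `COc1cc(N2C(N)=C(C#N)C(c3cccc([N+](=O)[O-])c3)C3=C2CC(C)(C)CC3=O)cc(OC)c1OC` gives 20%. Compound 2 stands second highest of the three numbers; its nearest neighbour is compound 1, within the scatter, while compound 3 lies beyond it, a number 15 percentage points higher from compound 2 to compound 3 (beyond the scatter).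

Compound 4 `COc1cc(N2C(N)=C(C#N)C(c3ccc(C)cc3)C3=C2CC(C)(C)CC3=O)cc(OC)c1OC` differs from compound 2 as follows: 4-methylphenyl in place of 2-methoxynaphthalen-1-yl on a saturated ring carbon.

Among the compounds with values here, the steps that bear on this are a number 4 percentage points higher from compound 1 to compound 2 (within the scatter) and a number 15 percentage points higher from compound 2 to compound 3 (beyond the scatter). Only the 3-nitrophenyl compound moves the read-out beyond the scatter; the 4-methoxyphenyl and 2-methoxynaphthalen-1-yl compounds sit together near the bottom. The 4-methylphenyl entering here brings no nitro group, so the expected change is a number 2 percentage points lower from compound 2 to compound 4 (within the scatter), none beyond the scatter. Compound 4 is therefore estimated at 3%, with a range from 0% to 12%.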

Compound 4, a percentage reported as activity, at one concentration (the size of the read-out at that concentration, not a potency): 50%
For compound 4 the middle estimate is 47 percentage points below the measured one, outside the stated range (above it).
By their numbers in this assay, from the lowest: compounds 1 and 2 (each within the scatter of the next); then compound 3; then compound 4.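

Within the data shown here, the position tolerates far more than the earlier compounds suggested: a plain 4-methylphenyl gives a number 45 percentage points higher from compound 2 to compound 4 (beyond the scatter) in this assay and also exceeds the only earlier compound beyond the scatter, with a number 30 percentage points higher from compound 3 to compound 4 (beyond the scatter) on the same read-out, so a nitro group is not needed for a high number in this set. The change can also be as small as one substituent on the phenyl ring, since methyl in place of methoxy on an aromatic carbon gives a number 49 percentage points higher from compound 1 to compound 4 (beyond the scatter) and is a large step. Nothing available explains these steps.

Going by these compounds, whether the gain belongs to methyl in particular stays open, as an unsubstituted phenyl, 4-ethylphenyl or 4-chlorophenyl could show. On these data alone, with one concentration only, the potency of compound 4 also remains unknown.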